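The source may report more compounds than this note shows. Statements on the series, on what has been measured and on what is new or still open speak of the compounds shown alone.

Series notes. In a functional assay on HCT-15 cells (Homo sapiens) for antiproliferative activity, read by MTT assay, with a stated time of 72 h (on this read-out lower numbers stand for stronger inhibition and higher numbers for weaker inhibition), compound 1 `COc1cc(-c2nccn2C)cc(OC)c1OC` gives only a limit, > 100000 nM. Compound 2 `CCn1ccnc1-c1cc(OC)c(OC)c(OC)c1` likewise returns a limit in this assay, > 100000 nM. Compound 3 `COc1cc(-c2nccn2CC(C)C)cc(OC)c1OC`, the starting point for the step at hand, also sits at a limit in this assay, > 100000 nM. The steps a step that the two limits leave unreadable from compound 1 to compound 2, a step that the two limits leave unreadable from compound 1 to compound 3 and a step that the two limits leave unreadable from compound 2 to compound 3 are all unreadable, since every value shown rests at the limit of > 100000 nM in this assay, at which 3 of the 3 values shown sit. Compound 4 `COc1cc(-c2nccn2-c2ccc(C)cc2)cc(OC)c1OC` carries 4-methylphenyl in place of isobutyl on an aromatic nitrogen. Going by the values given here, none of the measured steps concerns an aromatic group on the aromatic nitrogen, and none has a readable size, so no direction can be drawn from them. Compound 4 is therefore expected to remain near the limit, estimated at 100000 nM (range 30000 nM to 300000 nM). The step from compound 3 to compound 4 is thus estimated as a number no higher from compound 3 to compound 4 (the limit leaves the size open).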

Compound 4, half-maximal inhibitory concentration: 800 nM
For compound 4 the middle estimate is 130-fold (2.10 log units) above the measured one; measured number outside the range, below it.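

In this assay, going by these compounds alone, the aromatic nitrogen of the shared core is the first place where a change gives a readable gain: 4-methylphenyl in place of isobutyl gives an at least 120-fold lower number from compound 3 to compound 4 (2.09 log units; beyond the scatter), in place of ethyl gives an at least 120-fold lower number from compound 2 to compound 4 (2.09 log units; beyond the scatter), and in place of methyl gives an at least 120-fold lower number from compound 1 to compound 4 (2.09 log units; beyond the scatter). The true size of each step stays open, and the steps among compound 1, compound 2 and compound 3 cannot be read: the limit of > 100000 nM in this assay, at which 3 of the 4 values shown sit.

As far as these compounds go, compound 4 alone stands off the limit, so it remains open whether the six-membered aromatic ring or its methyl accounts for the step. Plain phenyl or benzyl on the same nitrogen would separate the two.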